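Amide series: benzylamino in place of 2-fluorophenylamino

This account rests on a few compounds, and the source may have more. Where it says the series, first, only, none or still open, it means among the compounds named here.

Measured so far in an in vitro assay on HEK-tsA201 cells for antagonist activity at Neuronal acetylcholine receptor; alpha3/beta4 (Homo sapiens), read by fluorescence and calcium flux; on this read-out higher numbers stand for weaker inhibition and lower numbers for stronger inhibition:
- compound 1 `CCCOc1ccc(C(=O)Nc2cccc(Br)n2)cc1`: compound 1 gives > 100000 nM, a limit of the assay.
- compound 2 `CCCCNc1cccc(NC(=O)c2ccc(OCCC)cc2)n1`: compound 2 gives 77800 nM.
- compound 3 `CCCOc1ccc(C(=O)Nc2cccc(Nc3ccccc3F)n2)cc1`: compound 3 gives > 100000 nM, a limit of the assay.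

Compound 3 sits at the limit of > 100000 nM in this assay, at which 2 of the 3 values shown sit, so only a limit is known for it, and the step that the two limits leave unreadable from compound 1 to compound 3 cannot be sized. The two readable steps are small: an at least 1.2-fold lower number from compound 1 to compound 2 (0.10 log units; that floor lies within the scatter) and an at least 1.2-fold higher number from compound 2 to compound 3 (0.10 log units; that floor lies within the scatter); both carry a floor that lies within the scatter, so none of the three compounds separates from the others beyond it.

Compound 4 `CCCOc1ccc(C(=O)Nc2cccc(NCc3ccccc3)n2)cc1` differs from compound 3 by benzyl in place of 2-fluorophenyl on a nitrogen on an aromatic ring. The nearest measured step is the exchange of butyl for 2-fluorophenyl on that same nitrogen, and it moved the number by no more than the scatter allows to read. Going from 2-fluorophenyl to benzyl on that nitrogen is therefore expected to stay close to where compound 3 stands, with no step beyond the scatter in this assay in either direction; the expected step is a step that the limit leaves unreadable from compound 3 to compound 4.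

Compound 4 is estimated at 120000 nM, with a range from 40000 nM to 400000 nM, and a fair chance that the assay again returns only a limit.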

Compound 4, half-maximal inhibitory concentration: > 100000 nM
Compound 4: a limit, no number; the forecaster's own chance of this, stated with the estimate: 55%; the middle value is on the limit's open side.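

In this assay compound 4 gives > 100000 nM, a limit of the assay, so benzylamino at this position, with the ring held on a saturated chain carbon, gives no number, just as (2-fluorophenyl)amino gave none. Set against the butyl chain on the same nitrogen, the only group on it with a number so far, the exchange gives an at least 1.2-fold higher number from compound 2 to compound 4 (0.10 log units; that floor lies within the scatter), so a phenyl in place of the propyl part of that chain does not separate beyond the scatter. The steps to compound 4 from compound 3 and from compound 1 cannot be read, because both ends of each are limits: the limit of > 100000 nM in this assay, at which 3 of the 4 values shown sit.

Going by these compounds, whether any group on this nitrogen can move the number beyond the scatter from compound 2 stays open, for example a longer chain or a chain ending in an amine or a carboxylic acid. On these data alone, it also stays open whether a saturated ring such as cyclohexyl or piperidine, in place of the benzyl ring, gives a number at all in this assay.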